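Fluoro on the Anilide Ring of a Thiosemicarbazone Series

The source may report more compounds than this note shows. Statements on the series, on what has been measured and on what is new or still open speak of the compounds shown alone.

Compound 2 `CC(=NNC(=S)Nc1ccccc1)c1ccccn1` and compound 3 `C/C(=N\NC(=S)Nc1ccccc1)c1ccccn1` share the same atoms and bonds; they differ only in that (the two compounds have the same atoms and bonds; at least one stereo element is drawn with a configuration in one of them and without one in the other: 1 of 1 stereo elements differ; a double bond is drawn without a configuration in compound 2 and E in compound 3). In a functional assay on T98G cells (Homo sapiens) for cytotoxicity, read by MTT assay, with a stated time of 48 h (on this read-out lower numbers stand for stronger inhibition and higher numbers for weaker inhibition), compound 2 gives 6.8 nM and compound 3 gives 6.81 nM, a difference of a 1.0-fold higher number from compound 2 to compound 3 (0.00 log units; within the scatter), which fits with the fact that one of compounds 2 and 3 is drawn with a defined configuration and the other without, at the place where they differ. Compound 1 `CC(=NNC(=S)Nc1ccccc1F)c1ccccn1` carries fluoro in place of hydrogen on an aromatic carbon, and in this assay compound 1 gives 3.1 nM, so the step is a 2.2-fold lower number from compound 2 to compound 1 (0.34 log units; beyond the scatter). Compound 4 `C/C(=N\NC(=S)Nc1ccc(F)cc1)c1ccccn1` carries fluoro in place of hydrogen on an aromatic carbon; this is the same kind of change as from compound 2 to compound 1, but the place differs, ortho to a large group there and para to a large group here. From compound 3 to compound 4 the step is expected to be a 1.5-fold lower number from compound 3 to compound 4 (0.18 log units; within the scatter), resting on the step of a 2.2-fold lower number from compound 2 to compound 1 (0.34 log units; beyond the scatter) and on the similar numbers of compound 2 and compound 3. Compound 4 is therefore estimated at 4.5 nM, between 2.5 nM and 9 nM.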

Compound 4, half-maximal inhibitory concentration: 17 nM
Beside the measured number, compound 4's estimate is 3.8-fold (0.58 log units) below it; measured number outside the range, above it.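

In this assay, the fluoro change does not repeat its earlier direction when it stands para to a large group, giving a 2.5-fold higher number from compound 3 to compound 4 (0.40 log units; beyond the scatter). The same change therefore does not carry from one compound pair to the other as a fixed step in this series: the same change on two cores in this assay, a 2.2-fold lower number (0.34 log units; beyond the scatter) from compound 2 to compound 1 and a 2.5-fold higher number (0.40 log units; beyond the scatter) from compound 3 to compound 4, 5.5-fold (0.74 log units) apart, beyond the scatter of two such steps. This does not show why the two steps part, since the fluoro stands at a different place in each pair, and two steps alone cannot say whether that place accounts for the gap.

As far as these compounds go, it remains open how a chloro or a methoxy group at the same place would compare with fluoro. From the compounds shown here alone, whether an amine there would follow either step also remains open.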